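The source may report more compounds than this note shows. Statements on the series, on what has been measured and on what is new or still open speak of the compounds shown alone.

Measured compounds in a functional assay on SK-OV-3 cells (Homo sapiens) for antiproliferative activity, read by MTT assay, with a stated time of 24 h; on this read-out lower numbers stand for stronger inhibition and higher numbers for weaker inhibition:
- compound 1, `COc1cc(OC)c(OC)cc1/C=C/C(=O)c1ccc(OC)c2c1OC(C)(C)C=C2`: > 10000 nM, a limit of the assay, not a number
- compound 2, `COc1ccc(C(=O)/C=C/c2ccc3ccccc3n2)c2c1C=CC(C)(C)O2`: 2350 nM
- compound 3, `COc1ccc(C(=O)/C=C/c2ccsc2)c2c1C=CC(C)(C)O2`: > 10000 nM, a limit of the assay, not a number

Compound 3 therefore has no measured number in this assay, only (the limit of > 10000 nM in this assay, at which 2 of the 3 values shown sit). Of the three values shown, only compound 2 carries a number; the values of compound 1 and compound 3 show nothing beyond that both sit at the limit. Among the measured compounds shown here, no pair among the three differs in one place, so no measured step is available to size the change below.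

Compound 4, `COc1ccc(C(=O)/C=C/c2cccc(O)c2)c2c1C=CC(C)(C)O2`, is not yet measured in this assay. It differs from compound 3 by 3-hydroxyphenyl in place of thiophen-3-yl on a double-bonded chain carbon bound to a double-bonded chain carbon. For the measured compounds named here, with no measured step to lean on, the expectation for this assay is drawn only from the values shown: compound 2 is the single compound with a number, and compound 3 sits at the limit. The step from compound 3 is expected to be an at least 2.0-fold lower number from compound 3 to compound 4 (0.30 log units; that floor lies within the scatter), that is, a move from the limit into the measurable range, though a further limit would not be a surprise. For compound 4 the estimate in this assay is 5000 nM, within 1500 nM to 20000 nM.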

Compound 4, half-maximal inhibitory concentration: > 10000 nM
Compound 4: no number, only a limit (the forecaster's own chance of this, stated with the estimate: 40%); at least 2.0-fold (0.30 log units) between middle value and limit.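

In this assay compound 3 and compound 4 both stand at a limit of the assay, not at a number, so no step between them can be read: the limit of > 10000 nM in this assay, at which 3 of the 4 values shown sit.

The compounds shown leave open the size and direction of any change on going from thiophen-3-yl to 3-hydroxyphenyl.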